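Moving from 3-chlorobenzyl to 4-bromo-2-chlorobenzyl

The compounds below may be only part of what the source reports. "The series", "measured", "known", "first", "only" and "open" are said of these compounds alone.

Compound 1 `O=c1c2cnn(-c3ccc(F)cc3)c2ncn1CC1(O)CCN(Cc2ccccn2)CC1` gives "not determined" (no result reported) in an assay on Sf21 cells for inhibition of ubiquitin carboxyl-terminal hydrolase 7 (Homo sapiens), read by spectrophotometry, with stated times of 30 min and 2 h; on this read-out lower numbers stand for stronger inhibition and higher numbers for weaker inhibition.
Compound 2 `O=c1c2cnn(-c3ccc(F)cc3)c2ncn1CC1(O)CCN(Cc2ccccc2Cl)CC1` gives 3400 nM in this assay.
Compound 3 `O=c1c2cnn(-c3ccc(F)cc3)c2ncn1CC1(O)CCN(Cc2cccc(Cl)c2)CC1` gives "not determined" (no result reported) in this assay.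

Of the three measured compounds, only compound 2 carries a number in this assay; compound 1 and compound 3 have no result reported, so compound 3 stands without a value of its own. Compound 4 `O=c1c2cnn(-c3ccc(F)cc3)c2ncn1CC1(O)CCN(Cc2ccc(Br)cc2Cl)CC1` differs from compound 3 in one place: 4-bromo-2-chlorophenyl in place of 3-chlorophenyl on a saturated chain carbon bound to an amine nitrogen in a ring. For the measured compounds named here, with no measured step to lean on, the size of the change in this assay cannot be read from the data; a modest step, not clearly beyond the scatter, in either direction is the most that can be expected. Taking the number of compound 2 as the nearest reference, compound 4 is estimated to give 2500 nM, within a range from 700 nM to 9000 nM.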

Compound 4, half-maximal inhibitory concentration: 1900 nM
Compound 4: the middle estimate sits 1.3-fold (0.12 log units) above what was measured, within the range that was stated.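

Bromo in place of hydrogen on an aromatic carbon gives a 1.8-fold lower number from compound 2 to compound 4 (0.25 log units; within the scatter) in this assay. The ring of compound 2 therefore carries this bromo with no clear gain or loss, the first thing the numbers show about substitution on this benzyl group. Compound 3 has no number, so the step from 3-chlorobenzyl to 4-bromo-2-chlorobenzyl cannot be read. Nothing measured here offers an explanation for the result. As far as these compounds go, whether an amine or a carboxylic acid on that aromatic carbon would move the number beyond the scatter stays open.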